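The compounds below may be only part of what the source reports. "The series", "measured", "known", "first", "only" and "open" are said of these compounds alone.

Measured so far:
compound 1 `COc1ccccc1Oc1ccc2c(NCCCNCc3ccco3)ccnc2c1`, 6500 nM
compound 2 `COc1ccc(Oc2ccc3c(NCCCNCc4cccc(OC)c4O)ccnc3c2)cc1`, 5500 nM

Both numbers come from an ADME assay on HepG2 cells (Homo sapiens) for cytotoxicity, read by luminescence, CellTiter-Glo and ATP content, with a stated time of 72 h; on this read-out higher numbers stand for an effect only at larger amounts of compound and lower numbers for an effect already at smaller amounts. Compound 1 gives 6500 nM, and compound 2 gives 5500 nM; the two values lie within the usual scatter of each other, so the two compounds cannot be told apart in this assay. Going by the values given here, no step between measured compounds differing in one place is available for this series.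

Compound 3 `Cc1cc(C)cc(Cc2ccc3c(NCCCNCc4ccco4)ccnc3c2)c1` is not yet measured. Relative to compound 1 it carries 3,5-dimethylbenzyl in place of 2-methoxyphenoxy on an aromatic carbon. The change keeps the shared core and the three-carbon chain with the furan-containing end intact; only the aromatic substituent changes.

Among the compounds with values here, with no measured pair to set the size of such a step, the expected step of a 1.4-fold lower number from compound 1 to compound 3 (0.16 log units; within the scatter) is small, of a size that need not exceed the scatter, with no firm direction. Compound 3 is therefore estimated at 4500 nM, with a range from 1500 nM to 14000 nM.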

Compound 3, half-maximal effective concentration: 6270 nM
For compound 3 the middle estimate is 1.4-fold (0.14 log units) below the measured one, and the stated range covers the measured number.
By their numbers in this assay, from the lowest: compounds 2, 3 and 1 (each within the scatter of the next).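

In this assay, going by these compounds alone, placing 3,5-dimethylbenzyl in place of 2-methoxyphenoxy on this aromatic carbon gives a 1.0-fold lower number from compound 1 to compound 3 (0.02 log units; within the scatter) and provides the only one-place step, so compound 1 and compound 3 cannot be told apart. At this position, the read-out therefore does not separate a group with two oxygen atoms and hydrogen-bond acceptors from an all-carbon group with none, at the same heavy-atom count. Nothing available bears on why the read-out holds across this change.

Going by these compounds, it remains open whether the same flat step would hold with an amine or a carboxylic acid on this aromatic carbon. Equally open, on these data alone, is whether a longer chain in place of the three-carbon chain would leave the read-out within the scatter.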